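Bromo to Iodo on an Aryl Urea, Second Position

The source may hold more compounds than are shown below. What is called first, only, known or untested is meant among the compounds shown, and "the series" means these compounds.

Compound 1 `C[C@H](NC(=O)Nc1ccccc1Br)c1ccccc1` and compound 3 `C[C@H](NC(=O)Nc1ccccc1I)c1ccccc1` share one core, while compound 2 `C[C@@H](NC(=O)Nc1ccc(Br)cc1)c1ccccc1` and compound 4 `C[C@@H](NC(=O)Nc1ccc(I)cc1)c1ccccc1` share another; how the two cores differ is not broken down here. In an ADME assay on the whole organism with Oryza sativa as the target, tested at 1 uM (on this read-out lower numbers stand for a stronger effect and higher numbers for a weaker effect at the one concentration tested), compound 1 gives 99%. Compound 3 gives 100% in this assay, and compound 2 gives 95%. For the measured compounds named here, the single change between compound 1 and compound 3 is iodo in place of bromo on an aromatic carbon. That change made a step of a number 1 percentage points higher from compound 1 to compound 3 (within the scatter). The change from compound 2 to compound 4 is iodo in place of bromo on an aromatic carbon, the same kind of change, made ortho to a large group in the first pair and para to a large group in the second. Compound 4 has not yet been tested in this assay. Because a number 1 percentage points higher from compound 1 to compound 3 (within the scatter) stayed within the scatter, the step from compound 2 to compound 4 is expected to be about a number 1 percentage points higher from compound 2 to compound 4 (within the scatter). For compound 4 the expected result in this assay is 96%, with a likely range from 88% to 100%.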

Compound 4, a percentage reported as activity, at one concentration (the size of the read-out at that concentration, not a potency): 91%
For compound 4 the middle estimate is 5 percentage points above the measured one, and the stated range covers the measured number.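

In this assay, the exchange of bromo for iodo para to a large group gave a number 4 percentage points lower from compound 2 to compound 4 (within the scatter). Set beside the same exchange on the other core, the two steps cannot be told apart: the same change on two cores in this assay, a number 1 percentage points higher (within the scatter) from compound 1 to compound 3 and a number 4 percentage points lower (within the scatter) from compound 2 to compound 4, 5 percentage points apart, within the scatter of two such steps. On these two pairs, then, the exchange carried from one core to the other without a step on either that stands out from the scatter, but two pairs support no general rule, and neither step shows that the exchange would stay as small on any further core in this series.

The compounds shown carry only bromo or iodo on this aromatic ring, so it remains open what a chloro group, a methoxy group or a carboxylic acid would give there in this assay. As far as these compounds go, it also remains open whether a change elsewhere in the molecule, such as a longer chain in place of the methyl group, would give a step that rises beyond the scatter.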